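Exchanging a dichlorophenyl for a hydroxyphenyl on the imine

This account rests on a few compounds, and the source may have more. Where it says the series, first, only, none or still open, it means among the compounds named here.

Compound 2 `Clc1ccc(/C=N/c2sc3c(c2-c2nc4ccccc4s2)CCC3)c(Cl)c1` is one of two measured compounds. In an ADME assay on cells (Rhabdomyosarcoma cell, Homo sapiens) for cytotoxicity, read by MTT assay, with a stated time of 72 h (a lower number here means that less compound is tolerated, a higher number that more compound is tolerated), compound 2 gives 160 ug/mL, the higher of the two numbers. Compound 1 `Clc1ccccc1/C=N/c1sc2c(c1-c1nc3ccccc3s1)CCC2` carries a hydrogen where compound 2 carries a chlorine, and in this assay compound 1 gives 123 ug/mL. Those two numbers lie close together: a 1.3-fold higher number from compound 1 to compound 2 (0.11 log units; within the scatter). Compound 3 `Oc1ccccc1/C=N/c1sc2c(c1-c1nc3ccccc3s1)CCC2` has not yet been measured. It differs from compound 2 in that (2-hydroxyphenyl in place of 2,4-dichlorophenyl on a carbon with a double bond to nitrogen). Among the measured compounds shown here, the only measured step, a hydrogen exchanged for a chlorine, stayed within the scatter; no measured step adds or removes a hydroxyl group, so nothing here shows what that does. Compound 3 is therefore expected to differ from its neighbour by about a 1.2-fold lower number from compound 2 to compound 3 (0.09 log units; within the scatter), a step not expected to exceed the scatter. Compound 3 is estimated at 130 ug/mL, with a likely range from 60 ug/mL to 280 ug/mL.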

Compound 3, half-maximal cytotoxic concentration: 100 ug/mL
Compound 3: middle estimate off by 1.3-fold (0.11 log units), on the high side; low and high end bracket the measured number.
By their numbers in this assay, from the lowest: compounds 3, 1 and 2 (each within the scatter of the next).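

In this assay, 2-hydroxyphenyl in place of 2,4-dichlorophenyl on a carbon with a double bond to nitrogen gives a 1.6-fold lower number from compound 2 to compound 3 (0.20 log units; within the scatter), and hydroxy in place of chloro on an aromatic carbon gives a 1.2-fold lower number from compound 1 to compound 3 (0.09 log units; within the scatter). The earlier step only exchanged a hydrogen for a chlorine, whereas these steps show that a group with a hydrogen-bond donor and acceptor can enter this place, in exchange for chlorine-bearing groups with neither, without the number leaving the scatter. No supporting measurement is available to explain this outcome. From the compounds shown here alone, whether an amine or a carboxylic acid on the phenyl ring would move the number beyond the scatter remains open. So does the outcome of replacing the phenyl ring with a longer chain or changing the shared core.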